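The source may hold more compounds than are shown below. What is called first, only, known or untested is meant among the compounds shown, and "the series" means these compounds.

Measured so far in a functional assay on PC-3 cells (Homo sapiens) for antiproliferative activity, read by MTT assay, with a stated time of 48 h; on this read-out higher numbers stand for weaker inhibition and lower numbers for stronger inhibition:
compound 1, `CS(=O)(=O)c1ccc(Nc2ncc(F)c(Nc3nc4ccccc4s3)n2)cc1`, gives 2830 nM.
compound 2, `NS(=O)(=O)c1ccc(Nc2ncc(F)c(Nc3nc4ccccc4s3)n2)cc1`, gives only a limit of the assay, > 50000 nM, and not a number.
compound 3, `NS(=O)(=O)c1ccc(Nc2ncc(F)c(Nc3nc4ccc(Cl)cc4s3)n2)cc1`, gives 1430 nM.

Compound 1 differs from compound 2 by methyl in place of amino on a sulfonyl sulfur. That change brought an at least 17-fold lower number from compound 2 to compound 1 (1.24 log units; beyond the scatter). Only a floor for this step is known, since compound 2 sits at the limit of > 50000 nM in this assay, at which 1 of the 3 values shown sits. Compound 3 differs from compound 2 by chloro in place of hydrogen on an aromatic carbon, which brought an at least 34-fold lower number from compound 2 to compound 3 (1.54 log units; beyond the scatter), again measured only as a floor from the same limit. Compound 3 and compound 1 lie within the usual scatter of each other.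

Compound 4, `CS(=O)(=O)c1ccc(Nc2ncc(F)c(Nc3nc4ccc(Cl)cc4s3)n2)cc1`, is not yet measured. It differs from compound 3 by methyl in place of amino on a sulfonyl sulfur, the same change that led from compound 2 to compound 1, made on a core carrying the chloro group. On these data alone, because the earlier step was an at least 17-fold lower number from compound 2 to compound 1 (1.24 log units; beyond the scatter), a downward step is expected here too, though its true size is unknown and a smaller step is plausible. The expected step is a 5.7-fold lower number from compound 3 to compound 4 (0.76 log units; beyond the scatter). Compound 4 is estimated at 250 nM, roughly between 60 nM and 1200 nM.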

Compound 4, half-maximal inhibitory concentration: > 50000 nM
Compound 4: no number, only a limit (the forecaster's own chance of this, stated with the estimate: 0%); middle value at least 200-fold (2.30 log units) away from the limit.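

The change does not carry over from one core to the other. In this assay, methyl in place of amino on a sulfonyl sulfur brought an at least 34-fold higher number from compound 3 to compound 4 (1.54 log units; beyond the scatter), the opposite direction to the earlier step on the core without chloro: the same change on two cores in this assay, an at least 17-fold lower number (1.24 log units; beyond the scatter) from compound 2 to compound 1 and an at least 34-fold higher number (1.54 log units; beyond the scatter) from compound 3 to compound 4, at least 610-fold (2.79 log units) apart, beyond the scatter of two such steps

Chloro in place of hydrogen on an aromatic carbon reverses in the same way, bringing an at least 17-fold higher number from compound 1 to compound 4 (1.24 log units; beyond the scatter), against the earlier step on the amino-bearing core: the same change on two cores in this assay, an at least 34-fold lower number (1.54 log units; beyond the scatter) from compound 2 to compound 3 and an at least 17-fold higher number (1.24 log units; beyond the scatter) from compound 1 to compound 4, at least 610-fold (2.79 log units) apart, beyond the scatter of two such steps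

Compound 4 gives > 50000 nM, a limit of the assay and not a number, so both new steps are known only as floors, and these four compounds do not show why the two changes fail to add up.

Still open, on these data alone, is whether the reversal is particular to chloro, or also appears with fluoro or methoxy on that aromatic carbon. As far as these compounds go, it is equally open how ethyl or a dimethylamino group on the sulfonyl sulfur would behave on either core.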